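Chloro Added on the Benzyloxy Ring of a Urea Analog

A few compounds are considered here, and "the series" means these few. Any claim that something is new, unique, unknown or untested is made for them only; others in the source may bear on it.

The measured compounds in a functional assay on MGC-803 cells (Homo sapiens) for inhibition, read by MTT assay, with a stated time of 48 h; on this read-out higher numbers stand for weaker inhibition and lower numbers for stronger inhibition:
compound 1 `Cc1ccc(NC(=S)NC(=O)c2ccc(OCc3cccc(Cl)c3)cc2)cc1-c1nc2ccccc2[nH]1` gives 51300 nM.
compound 2 `Cc1ccc(NC(=S)NC(=O)c2ccc(OCc3cccc(Cl)c3Cl)cc2)cc1-c1nc2ccccc2[nH]1` gives > 100000 nM, which is a limit of the assay and not a number.
compound 3 `Cc1ccc(NC(=O)NC(=O)c2ccc(OCc3ccccc3)cc2)cc1-c1nc2ccccc2[nH]1` gives 39400 nM.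

Compound 1 and compound 2 differ by chloro in place of hydrogen on an aromatic carbon, and the outcome is an at least 1.9-fold higher number from compound 1 to compound 2 (0.28 log units; that floor lies within the scatter); the size of that step is bounded only by the limit of > 100000 nM in this assay, at which 1 of the 3 values shown sits. How the core of compound 3 differs from the core of compound 1 is not broken down here; compound 3 and compound 1 give numbers within the scatter of each other.

Compound 4 `Cc1ccc(NC(=O)NC(=O)c2ccc(OCc3cccc(Cl)c3)cc2)cc1-c1nc2ccccc2[nH]1` has not been measured. It differs from compound 3 by chloro in place of hydrogen on an aromatic carbon. Among the measured compounds shown here, this is the same kind of change as the one between compound 1 and compound 2, but not the same: there the entering chloro sat ortho to a chloro group and ortho to a large group, whereas here it sits meta to a large group. Resting on an at least 1.9-fold higher number from compound 1 to compound 2 (0.28 log units; that floor lies within the scatter), the expected step is a 1.6-fold higher number from compound 3 to compound 4 (0.22 log units; within the scatter), a weakening of similar size that stays within the scatter. Compound 4 is therefore estimated to give 65000 nM in this assay, with a range from 25000 nM to 170000 nM.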

Compound 4, half-maximal inhibitory concentration: 20800 nM
Compound 4: middle estimate off by 3.1-fold (0.49 log units), on the high side; measured number below the stated range.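

In this assay, chloro in place of hydrogen on an aromatic carbon gives a 1.9-fold lower number from compound 3 to compound 4 (0.28 log units; within the scatter), a step that on its own stays within the scatter. Set beside the earlier step, it shows that this kind of change does not carry over with one size between the two cores: the same change on two cores in this assay, an at least 1.9-fold higher number (0.28 log units; that floor lies within the scatter) from compound 1 to compound 2 and a 1.9-fold lower number (0.28 log units; within the scatter) from compound 3 to compound 4, at least 3.6-fold (0.56 log units) apart, beyond the scatter of two such steps The two steps differ in both the core and the place where the chloro enters, so the compounds do not separate those two factors, and the earlier step is open-ended, resting on a limit of the assay and not a number: the limit of > 100000 nM in this assay, at which 1 of the 4 values shown sits.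

The compounds shown leave open how the plain benzyloxy group behaves on the core of compound 1, and whether a second chloro on the 3-chlorobenzyl group of compound 4 would repeat the earlier step. They also leave open whether a fluoro or a methoxy group in place of the chloro would give a step of similar size on either core.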